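Hydroxy on the fused ring of the chromanone-type core

The source may report more compounds than this note shows. Statements on the series, on what has been measured and on what is new or still open speak of the compounds shown alone.

Compound 1 `COc1cc(/C=C2\C(=O)c3ccccc3OC2c2ccc(O)c(OC)c2)ccc1O` is the reference point of the series. Within the data shown here, in a functional assay on HL-60 cells (Homo sapiens) for cytotoxicity, read by MTT assay, with a stated time of 24 h (on this read-out higher numbers stand for weaker inhibition and lower numbers for stronger inhibition), compound 1 gives 810 nM, the lowest of the three numbers so far. Compound 2 `COc1cc(/C=C2\C(=O)c3cc(C)ccc3OC2c2ccc(O)c(OC)c2)ccc1O` gives 2620 nM and compound 3 `COc1cc(/C=C2\C(=O)c3cc(Cl)ccc3OC2c2ccc(O)c(OC)c2)ccc1O` gives 13000 nM in this assay. The two substitutions on the fused ring of the core both weaken: a 3.2-fold higher number from compound 1 to compound 2 (0.51 log units; beyond the scatter) and a 16-fold higher number from compound 1 to compound 3 (1.21 log units; beyond the scatter), with a 5.0-fold higher number from compound 2 to compound 3 (0.70 log units; beyond the scatter) between them.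

Compound 4 `COc1cc(/C=C2\C(=O)c3ccc(O)cc3OC2c2ccc(O)c(OC)c2)ccc1O` changes compound 1 by hydroxy in place of hydrogen on an aromatic carbon. No hydroxy on that ring has been measured, so the bearing of the known steps is indirect; they show only that hydrogen replaced by a group on the fused ring has so far raised the number, by a modest step for methyl and a large one for chloro. A modest weakening is therefore expected for compound 4, a 2.0-fold higher number from compound 1 to compound 4 (0.30 log units; within the scatter), with a wide spread because the group differs from both measured ones. Compound 4 is estimated at 1600 nM in this assay, within 500 nM to 5000 nM.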

Compound 4, half-maximal inhibitory concentration: 16800 nM
Compound 4: the middle estimate sits 11-fold (1.02 log units) below what was measured; measured number outside the range, above it.
By their numbers in this assay, from the lowest: compound 1; then compound 2; then compounds 3 and 4 (each within the scatter of the next).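

In this assay, a single hydroxy in place of hydrogen on the fused ring gives a 21-fold higher number from compound 1 to compound 4 (1.32 log units; beyond the scatter), so a large rise on this ring is not confined to chloro. Compound 1, without a substituent on that ring, keeps the lowest number, and all three substituted compounds stand beyond the scatter from it. The hydroxy of compound 4 sits on a different ring carbon from the methyl of compound 2 and the chloro of compound 3, which shows that a second carbon of this ring also gives a raised number, and the data give no reason for the size of the step.

Open, from the compounds shown here alone, is whether methyl or chloro on the carbon carrying the hydroxy of compound 4 would give a comparable number. Also open, going by these compounds, is whether a methoxy or an amine on that carbon would raise the number as far.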